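From methylsulfanyl to methylsulfonyl: a step without measured guidance

The source may hold more compounds than are shown below. What is called first, only, known or untested is meant among the compounds shown, and "the series" means these compounds.

Measured in a functional assay on the whole organism for antagonist activity, with Mus musculus as the target; on this read-out higher numbers stand for an effect only at larger amounts of compound and lower numbers for an effect already at smaller amounts:
- compound 1 `CSc1n[nH]c(-c2ccc(F)cc2)n1`: > 200 mg/kg
- compound 2 `CSc1nnc(-c2ccc(F)cc2)n1C`: > 200 mg/kg
- compound 3 `CSc1nnc(-c2ccc(C)cc2)n1C`: > 100 mg/kg

Each of these values is a limit of the assay, not a number. Compound 3 stands at the limit > 100 mg/kg, which is the limit of > 100 mg/kg in this assay, at which 1 of the 3 values shown sits. The other two compounds stand at the limit of > 200 mg/kg in this assay, at which 2 of the 3 values shown sit.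

Compound 4 `Cc1ccc(-c2nnc(S(C)(=O)=O)n2C)cc1` differs from compound 3 in one place: methylsulfonyl in place of methylsulfanyl on an aromatic carbon. In words, methylsulfonyl stands in place of methylsulfanyl on an aromatic carbon.

Going by the values given here, the only measured step between two compounds is a step that the two limits leave unreadable from compound 2 to compound 3. That step puts methyl in place of fluoro on an aromatic carbon and leaves methylsulfanyl untouched, so it gives no size for the new change. Among the compounds with values here, no compound measured so far carries methylsulfonyl. Any expectation in this assay is therefore a loose judgement, and compound 4 may well return only a limit too. The expected step is an at least 1.6-fold lower number from compound 3 to compound 4 (0.22 log units; that floor lies within the scatter), tentatively towards smaller doses. Compound 4 is estimated at 60 mg/kg, with an expected range from 15 mg/kg to 200 mg/kg.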

Compound 4, dose for half-maximal effect: > 200 mg/kg
Compound 4: no number, only a limit; the forecaster's own chance of this, stated with the estimate: 35%; at least 3.3-fold (0.52 log units) between middle value and limit.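

Compound 3 and compound 4 each give only a limit, not a number, in this assay, and the step between them cannot be read. The compounds shown leave open whether methylsulfonyl in place of methylsulfanyl changes the dose needed at all, and in which direction.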